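The source may report more compounds than this note shows. Statements on the series, on what has been measured and on what is new or still open speak of the compounds shown alone.

Compound 2 `Cc1cccc(/C(N)=N/NC(=S)N2CCSCC2)n1` and compound 1 `N/C(=N\NC(=S)N1CCOCC1)c1ccccn1` share a thiosemicarbazone-type core and are both tested in a functional assay on A-431 cells (Homo sapiens) for cytotoxicity, read by MTT assay, with a stated time of 72 h; a lower number here means a stronger inhibitor, a higher number a weaker inhibitor. Compound 2 gives 2600 nM, the lower of the two numbers measured, while compound 1 gives 4800 nM; the gap between them lies within the scatter, so neither can be called the stronger inhibitor. The unmeasured compound 3 `Cc1cccc(/C(N)=N/NC(=S)N2CCOCC2)n1` keeps the core of compound 2 and carries one change: morpholin-4-yl in place of thiomorpholin-4-yl on a thiocarbonyl carbon. Compound 3 thus bears the same morpholin-4-yl group as compound 1, and the values of compound 1 and compound 2 sit close together. Among the measured compounds shown here, no measured pair here isolates this exchange, so the step from compound 2 to compound 3 is expected to be small, in either direction, or none beyond the scatter, a 1.3-fold higher number from compound 2 to compound 3 (0.13 log units; within the scatter). Compound 3 is therefore estimated to give 3500 nM in this assay, with a likely range from 1500 nM to 8000 nM.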

Compound 3, half-maximal inhibitory concentration: 4300 nM
Compound 3: middle estimate off by 1.2-fold (0.09 log units), on the low side; the range from low to high includes it.
By their numbers in this assay, from the lowest: compounds 2, 3 and 1 (each within the scatter of the next).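

Compound 3 puts a first measured size on the exchange of thiomorpholin-4-yl for morpholin-4-yl on a thiocarbonyl carbon: in this assay the step is a 1.7-fold higher number from compound 2 to compound 3 (0.22 log units; within the scatter) and stays within the usual scatter, so this exchange on the shared core cannot be told apart from repeat-measurement noise. It also gives a one-place comparison for methyl in place of hydrogen on an aromatic carbon, a 1.1-fold lower number from compound 1 to compound 3 (0.05 log units; within the scatter), and that step is equally unresolved. Nothing available here gives a reason for either step.

On these data alone, whether a piperazine ring or an open dimethylamino group on the thiocarbonyl carbon would shift the number beyond the scatter stays open, as does the effect of a longer chain such as ethyl on the aromatic carbon. Each step also rests on a single pair of compounds, so neither can be extended to other cores.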